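This account rests on a few compounds, and the source may have more. Where it says the series, first, only, none or still open, it means among the compounds named here.

Measured in a functional assay on NCI-H1975 cells (Homo sapiens) for antiproliferative activity; on this read-out higher numbers stand for weaker inhibition and lower numbers for stronger inhibition:

- Compound 1 `Cc1c2c(n3c1CCCN[C@@H](C)[C@H](C)Nc1cc-3ccc1C(N)=O)CC(C)(C)CC2=O`: 20 nM
- Compound 2 `Cc1c2c(n3c1CCN(C)C[C@@H](C)[C@H](C)Nc1cc-3ccc1C(N)=O)CC(C)(C)CC2=O`: 27 nM
- Compound 3 `Cc1c2c(n3c1CCN(C(=O)CN)C[C@@H](C)[C@H](C)Nc1cc-3ccc1C(N)=O)CC(C)(C)CC2=O`: 190 nM

Of these three, compound 3, at 190 nM, has the highest number and so shows the weakest inhibition. Compound 1 and compound 2 lie within the usual scatter of each other.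

The next compound to be tested is compound 4 `CC[C@H](N)C(=O)N1CCc2c(C)c3c(n2-c2ccc(C(N)=O)c(c2)N[C@@H](C)[C@H](C)C1)CC(C)(C)CC3=O`. It keeps the whole of compound 3 except for one change: ethyl in place of hydrogen on a saturated chain carbon bound to an amine nitrogen and a carbonyl carbon. The new ethyl sits on a saturated chain carbon bound to an amine nitrogen and a carbonyl carbon, within the group that compound 3 carries on its ring nitrogen.

Among the measured compounds shown here, only one measured step bears on this change: a 7.0-fold higher number from compound 2 to compound 3 (0.85 log units; beyond the scatter). That step put (aminomethyl)carbonyl in place of methyl on the amine nitrogen, so it shows that this nitrogen's substituent can shift the read-out. For the measured compounds named here, it does not test an ethyl group on the chain carbon, and no measured pair does. A smaller change than that one is therefore a reasonable expectation, with no firm direction and probably nothing beyond the scatter.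

The expected change is a 1.1-fold lower number from compound 3 to compound 4 (0.02 log units; within the scatter). For compound 4 the estimated value in this assay is 180 nM, with an expected range from 60 nM to 550 nM.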

Compound 4, half-maximal inhibitory concentration: 41 nM
Compound 4: the middle estimate sits 4.4-fold (0.64 log units) above what was measured; measured number outside the range, below it.
By their numbers in this assay, from the lowest: compounds 1, 2 and 4 (each within the scatter of the next, the first and the last beyond it); then compound 3.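

In this assay, among the compounds shown here, ethyl in place of hydrogen on the saturated chain carbon bound to an amine nitrogen and a carbonyl carbon turns aminomethyl into 1-aminopropyl and gives a 4.6-fold lower number from compound 3 to compound 4 (0.67 log units; beyond the scatter) so a small carbon group on this chain carbon can by itself move the read-out, which the earlier compounds could not show. The result also qualifies the earlier step on the amine nitrogen in the ring, where (aminomethyl)carbonyl in place of methyl gave a 7.0-fold higher number from compound 2 to compound 3 (0.85 log units; beyond the scatter) while (1-aminopropyl)carbonyl in the same place gives a 1.5-fold higher number from compound 2 to compound 4 (0.18 log units; within the scatter) so a group joined through a carbonyl at this nitrogen does not always cost inhibition beyond the scatter. No measured evidence here explains why the ethyl has this effect.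

The compounds shown leave open whether a methyl, a propyl or a benzyl group on this chain carbon would behave like the ethyl, and whether the opposite spatial arrangement at this carbon would give the same number. They also leave open how much the free amine of this group matters, which a hydroxyl in its place would test.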